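Quinolinone amide substituent: cyclopentenyl replaced by methoxy

The compounds below may be only part of what the source reports. "The series", "measured", "known", "first", "only" and "open" are said of these compounds alone.

Compound 1 `Cc1c(C(=O)Nc2ccc(Oc3ncnc4[nH]cc(-c5ccccc5)c34)c(F)c2)c(=O)c2ccccc2n1C`: in an assay on isolated protein for inhibition of tyrosine-protein kinase receptor UFO (Homo sapiens), read by FRET and Z'-LYTE, with a stated time of 1.5 h (a lower number here means a stronger inhibitor, a higher number a weaker inhibitor), compound 1 gives > 10000 nM, which is a limit of the assay, not a number.
Compound 2 `Cc1c(C(=O)Nc2ccc(Oc3ncnc4[nH]cc(-c5ccccc5)c34)c(F)c2)c(=O)c2cc(C3=CCCC3)ccc2n1C`: in this assay compound 2 gives 3320 nM.

Within the data shown here, compound 2 is the only compound with a measured number in this assay; the other value is a limit. Among the measured compounds shown here, the one measured step, an at least 3.0-fold lower number from compound 1 to compound 2 (0.47 log units; beyond the scatter), shows that placing a cyclopent-1-en-1-yl group where compound 1 carries hydrogen improves the number, though its size is uncertain because the limit of > 10000 nM in this assay, at which 1 of the 2 values shown sits, caps what compound 1 can show.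

Compound 3 `COc1ccc2c(c1)c(=O)c(C(=O)Nc1ccc(Oc3ncnc4[nH]cc(-c5ccccc5)c34)c(F)c1)c(C)n2C` differs from compound 2 by methoxy in place of cyclopent-1-en-1-yl on an aromatic carbon. This puts the methoxy group where compound 2 carries cyclopent-1-en-1-yl and compound 1 carries hydrogen. For the measured compounds named here, only the step from compound 1 to compound 2 bears on it, and it was at least modest. A smaller group at that position is expected to fall between the two: compound 3 is estimated at 6000 nM (2000 nM to 20000 nM), an expected step of a 1.8-fold higher number from compound 2 to compound 3 (0.26 log units; within the scatter), with a real chance that only a limit is returned.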

Compound 3, half-maximal inhibitory concentration: 99 nM
The estimate for compound 3 lay 61-fold (1.78 log units) above the measured number; measured number outside the range, below it.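

In this assay, this aromatic carbon proves far more sensitive to the identity of its group than the first pair could show, and the order of the groups does not follow a simple gain from adding bulk: methoxy in place of cyclopent-1-en-1-yl gives a 34-fold lower number from compound 2 to compound 3 (1.53 log units; beyond the scatter). Methoxy in place of hydrogen gives an at least 100-fold lower number from compound 1 to compound 3 (2.00 log units; beyond the scatter), so a ring is not needed at this position for a large step. That step is only a bound, since the value of compound 1 is a limit of the assay: the limit of > 10000 nM in this assay, at which 1 of the 3 values shown sits.

As far as these compounds go, it stays open whether the oxygen or the methyl of methoxy carries the step, which a hydroxyl, a fluorine or a methyl at this carbon would test. From the compounds shown here alone, whether a longer chain such as ethoxy or propoxy, or an amine, keeps the number of compound 3 also remains unknown.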